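The compounds below may be only part of what the source reports. "The series", "measured", "known", "first", "only" and "open" are said of these compounds alone.

Going by the values given here, in a functional assay on Z-138 cells (Homo sapiens) for inhibition, read by luminescence and CellTiter-Glo, with a stated time of 72 h (on this read-out higher numbers stand for weaker inhibition and lower numbers for stronger inhibition), compound 2 `C/C=C/C(=O)N1CCCC(n2nc(-c3ccc(Oc4ccccc4)cc3)cc2C(=O)OCC)C1` gives 19100 nM, the middle of the three numbers so far. Compound 1 `O=C(O)c1cc(-c2ccc(Oc3ccccc3)cc2)nn1C1CCCN(C(=O)CCl)C1` stands lower at 2800 nM, and compound 3 `C=CC(=O)N1CCCC(n2nc(-c3ccc(Oc4ccccc4)cc3)cc2C(=O)OCC)C1` stands higher at 44000 nM.

Compound 4 `C/C=C/C(=O)N1CCCC(n2nc(-c3ccc(Oc4ccccc4)cc3)cc2C(=O)O)C1` comes from compound 2 through one change: hydrogen in place of ethyl on an oxygen next to a carbonyl group. This turns the ethoxycarbonyl group into a carboxy group.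

Among the compounds with values here, only one measured step links compounds that differ in a single place, a 2.3-fold higher number from compound 2 to compound 3 (0.36 log units; beyond the scatter), and it is modest. That step replaces prop-1-en-1-yl with vinyl on a carbonyl carbon and leaves the ethoxycarbonyl group untouched, so it says nothing directly about this change and shows only how large a single change has been in this small set.

The closest hint comes from compound 1 at 2800 nM, which already carries the carboxy group, but it also differs from compound 4 in a second place. Within the data shown here, no measured pair isolates the swap from ethyl to hydrogen, so the direction remains tentative. A moderate move towards a lower number, and thus stronger inhibition, is expected: a 2.4-fold lower number from compound 2 to compound 4 (0.38 log units; beyond the scatter).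

For compound 4 the estimated value is 8000 nM, with an expected range from 2500 nM to 26000 nM.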

Compound 4, half-maximal inhibitory concentration: > 60000 nM
Compound 4: no number, only a limit; the forecaster's own chance of this, stated with the estimate: 8%; middle value at least 7.5-fold (0.87 log units) from the limit.
By their numbers in this assay, from the lowest: compound 1; then compound 2; then compound 3. At a limit, above all of these: compound 4.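

In this assay compound 4 gives no number but a limit, and that limit is the top of all the values shown: the limit of > 60000 nM in this assay, at which 1 of the 4 values shown sits. On the oxygen next to a carbonyl group, hydrogen in place of ethyl gives an at least 3.1-fold higher number from compound 2 to compound 4 (0.49 log units; beyond the scatter), so with prop-1-en-1-yl on the carbonyl carbon, going from ethoxycarbonyl to carboxy weakens inhibition rather than strengthening it. With the carboxy group held constant, prop-1-en-1-yl in place of chloromethyl on the carbonyl carbon gives an at least 21-fold higher number from compound 1 to compound 4 (1.33 log units; beyond the scatter), a large step, which shows that the lower number of compound 1 cannot be credited to the carboxy group alone and that the result at this oxygen depends on what sits on the carbonyl carbon.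

The compounds shown leave open how far compound 4 really lies past its limit, and whether the swap from ethyl to hydrogen runs the same way with chloromethyl or vinyl on the carbonyl carbon. They also leave open how a methoxycarbonyl group or a primary amide would compare with ethoxycarbonyl and carboxy in this place.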